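The source may hold more compounds than are shown below. What is called first, only, known or untested is meant among the compounds shown, and "the series" means these compounds.

The compounds share one core, carried by compound 1, `O=C(O)c1ccc(NCc2cccc(Oc3ccccc3)c2)cc1`, where a carboxy group stands on an aromatic carbon. In a functional assay on CHO cells for agonist activity at Free fatty acid receptor 1 (Homo sapiens) (on this read-out higher numbers stand for an effect only at larger amounts of compound and lower numbers for an effect already at smaller amounts), compound 1 gives only a limit, < 10000 nM. Compound 2, `O=C(O)CSc1ccc(NCc2cccc(Oc3ccccc3)c2)cc1`, bears a (carboxymethyl)sulfanyl group in its place and gives 324 nM in this assay. Compound 3, `CC(C)NC(=O)CCc1ccc(NCc2cccc(Oc3ccccc3)c2)cc1`, carries a 2-(isopropylcarbamoyl)ethyl group and gives 39.8 nM in this assay. Among the compounds with values here, the move an 8.1-fold lower number from compound 2 to compound 3 (0.91 log units; beyond the scatter) is the one readable step; the steps from compound 1 stay unreadable because of the limit (the limit of < 10000 nM in this assay, at which 1 of the 3 values shown sits). Compound 3 thus stands at the lowest of the two numbers, with compound 2 as its nearest neighbour. Compound 4, `CN(C)C(=O)CCc1ccc(NCc2cccc(Oc3ccccc3)c2)cc1`, differs from compound 3 by dimethylamino in place of isopropylamino on a carbonyl carbon. Within the data shown here, no measured step touches the amine part of the amide: each measured step exchanges the whole side chain on the aromatic carbon, so none of them bears directly on this change. The account therefore expects no step beyond the scatter in this assay, a 1.5-fold higher number from compound 3 to compound 4 (0.18 log units; within the scatter). It estimates compound 4 at 60 nM, between 15 nM and 250 nM.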

Compound 4, half-maximal effective concentration: 174 nM
For compound 4 the middle estimate is 2.9-fold (0.46 log units) below the measured one; measured number inside the range.
By their numbers in this assay, from the lowest: compound 3; then compounds 4 and 2 (each within the scatter of the next).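

Dimethylamino in place of isopropylamino on a carbonyl carbon gives a 4.4-fold higher number from compound 3 to compound 4 (0.64 log units; beyond the scatter) in this assay, so a change in the amine part of the amide alone moves the read-out beyond the scatter, which the earlier steps, each exchanging the whole side chain, could not show. The gain of compound 3 over compound 2 therefore does not extend to this other amide: 2-(dimethylcarbamoyl)ethyl in place of (carboxymethyl)sulfanyl gives a 1.9-fold lower number from compound 2 to compound 4 (0.27 log units; within the scatter). All steps from compound 1 remain unreadable because its value is a limit: the limit of < 10000 nM in this assay, at which 1 of the 4 values shown sits.

The compounds shown leave open whether this step goes with the amide hydrogen that leaves with isopropylamino or with the carbon groups on the nitrogen. Nothing here tells how a methylamino or a tert-butylamino group on that carbonyl carbon would read.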